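The compounds below may be only part of what the source reports. "The series", "measured", "known", "first", "only" and "open" are said of these compounds alone.

Measured compounds in a functional assay on A549 cells (Homo sapiens) for inhibition, read by CCK-8 assay, with a stated time of 48 h; a higher number here means a weaker inhibitor, a lower number a stronger inhibitor:
Compound 1, `COc1cc(-c2ccnc3cc(-c4ccc(Cl)cc4)nn23)cc(OC)c1OC`: 3070 nM
Compound 2, `COc1cc(-c2cc3nccc(-c4c[nH]c5ccccc45)n3n2)cc(OC)c1OC`: a limit of the assay, > 10000 nM
Compound 3, `COc1cc(-c2ccnc3cc(-c4cccc5c4ccn5CO)nn23)cc(OC)c1OC`: 1100 nM

Compound 1 holds the highest of the two numbers reported in this assay. Its nearest neighbour is compound 3, whose lower number sits beyond the usual scatter of repeated measurements. Compound 2 gives no number at all, only the limit (the limit of > 10000 nM in this assay, at which 1 of the 3 values shown sits), and is therefore not ranked against the other two.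

Compound 4, `COc1cc(-c2ccnc3cc(-c4cccc(C)c4)nn23)cc(OC)c1OC`, has not yet been measured in this assay. It differs from compound 1 in a single place: 3-methylphenyl in place of 4-chlorophenyl on an aromatic carbon. Going by the values given here, no measured pair in the set differs in only one place, so no step of this kind is available to guide the expectation, and the change keeps the count of heavy atoms, the ring type and the absence of donors and acceptors the same.

On that basis the author expects compound 4 to stay close to compound 1, with a step of a 1.1-fold higher number from compound 1 to compound 4 (0.06 log units; within the scatter) that falls within the scatter rather than beyond it in either direction. The estimated value for compound 4 in this assay is 3500 nM, with a likely range from 1500 nM to 8500 nM.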

Compound 4, half-maximal inhibitory concentration: 5730 nM
Compound 4: middle estimate off by 1.6-fold (0.21 log units), on the low side; measured number inside the range.
By their numbers in this assay, from the lowest: compound 3; then compounds 1 and 4 (each within the scatter of the next). At a limit, above all of these: compound 2.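

Going by these compounds alone, replacing 4-chlorophenyl with 3-methylphenyl on this aromatic carbon gives the first comparison in which only one place differs: in this assay, the replacement gives a 1.9-fold higher number from compound 1 to compound 4 (0.27 log units; within the scatter). This shows that the aromatic carbon tolerates this particular exchange, as the chlorine-bearing and methyl-bearing phenyl rings cannot be told apart in this read-out, even though both the substituent and its place on the ring differ. No measurement shown bears on why these two compounds fall so close together.

Within the data shown here, how much the chlorine or methyl matters on its own, and how much their place on the phenyl ring matters, stays open, as the single step changes both together. Also open, on these data alone, is whether an amine or a carboxylic acid on this phenyl ring, or a piperidine in its place, would move the number beyond the scatter.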